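Going from Methoxy to Ethoxy

The source may hold more compounds than are shown below. What is called first, only, known or untested is meant among the compounds shown, and "the series" means these compounds.

Of the compounds shown here, two with the same core have been measured in a functional assay (Nicotiana tabacum) (a higher number here means a weaker inhibitor, a lower number a stronger inhibitor), so far. Compound 1 `CCc1ccc(Nc2nc(SC)nc3ncccc23)cc1` gives 7150 nM in this test. Compound 2 `COc1ccc(Nc2nc(SC)nc3ncccc23)cc1` gives 9420 nM in the same test. Going by the values given here, these two values lie within the scatter of each other, so compound 2 cannot be told apart from its only measured neighbour.

Compound 3 `CCOc1ccc(Nc2nc(SC)nc3ncccc23)cc1` is built from compound 2 by one small edit, (methyl in place of hydrogen on a saturated chain carbon bound to an oxygen on an aromatic ring), that is, methyl in place of hydrogen on a saturated chain carbon bound to an oxygen on an aromatic ring. This turns methoxy into ethoxy. Among the compounds with values here, only one measured step bears on this edit: a 1.3-fold higher number from compound 1 to compound 2 (0.12 log units; within the scatter), which swaps ethyl for methoxy at the same place on the compound. Within the data shown here, that is thin evidence, since no measured pair shows this exact edit. Among the measured compounds shown here, still, the one available step stays within the scatter, so no clear shift in this assay is expected here. The expected step is a 1.0-fold lower number from compound 2 to compound 3 (0.02 log units; within the scatter), no larger than the scatter. For compound 3 the estimated value is 9000 nM, with an expected range from 4000 nM to 20000 nM as its limits.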

Compound 3, half-maximal inhibitory concentration: 5420 nM
Estimate against measurement, compound 3: 1.7-fold (0.22 log units) above; low and high end bracket the measured number.
By their numbers in this assay, from the lowest: compounds 3, 1 and 2 (each within the scatter of the next).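

In this assay, adding a methyl to the saturated chain carbon bound to an oxygen on an aromatic ring, which turns methoxy into ethoxy, gives a 1.7-fold lower number from compound 2 to compound 3 (0.24 log units; within the scatter), so this exact edit now has a measured pair of its own and the extra carbon brings no readable shift. Replacing ethyl with ethoxy on the same aromatic carbon gives a 1.3-fold lower number from compound 1 to compound 3 (0.12 log units; within the scatter), which means that compound 1, compound 2 and compound 3 all lie within the scatter of one another, and ethyl, methoxy and ethoxy cannot be told apart at this place on the shared core. Nothing measured here offers an explanation for the small differences among these three compounds.

The compounds shown leave open whether a longer chain such as propoxy, or a quite different group such as an amine or a carboxylic acid, on this aromatic carbon would move the number beyond the scatter. They also leave open whether the methoxy to ethoxy edit would give a similarly small step on any other core.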